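Saturating the Side Chain of Compound 2

The source may hold more compounds than are shown below. What is called first, only, known or untested is meant among the compounds shown, and "the series" means these compounds.

In a functional assay on HeLa cells (Homo sapiens) for antiproliferative activity, read by MTT assay, with a stated time of 48 h (on this read-out lower numbers stand for stronger inhibition and higher numbers for weaker inhibition), compound 1 (`COc1cc(CNC(=O)CCCCCCC(C)C)ccc1OCCCCOc1ccc(C(N)=S)cc1`) gives 40700 nM and compound 2 (`COc1cc(CNC(=O)CCCC/C=C/C(C)C)ccc1OCCCCOc1ccc(-c2cc(=S)ss2)cc1`) gives 47100 nM, so compound 2 stands within the usual scatter of compound 1. Compound 3 (`COc1cc(CNC(=O)CCCCCCC(C)C)ccc1OCCCCOc1ccc(-c2cc(=S)ss2)cc1`) has not yet been measured. It differs from compound 2 as follows: isopentyl in place of 3-methylbut-1-en-1-yl on a saturated chain carbon, four bonds along the chain from a carbonyl carbon, with isopentyl in place of 3-methylbut-1-en-1-yl on a saturated chain carbon, four bonds along the chain from a carbonyl carbon. Going by the values given here, no measured pair isolates this change, so no step beyond the scatter is expected in this assay, and neither direction is favoured. The expected step is a 1.0-fold lower number from compound 2 to compound 3 (0.02 log units; within the scatter). For compound 3 the estimated value is 45000 nM, with an expected range of 24000 nM to 85000 nM.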

Compound 3, half-maximal inhibitory concentration: 44700 nM
Estimate against measurement, compound 3: 1.0-fold (0.00 log units) above, within the range that was stated.
By their numbers in this assay, from the lowest: compounds 1, 3 and 2 (each within the scatter of the next).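

In this assay, isopentyl in place of 3-methylbut-1-en-1-yl on a saturated chain carbon, four bonds along the chain from a carbonyl carbon, gives a 1.1-fold lower number from compound 2 to compound 3 (0.02 log units; within the scatter), so at this position the double bond makes no difference beyond the scatter. With the saturated chain in both compounds, the group with one five-membered aromatic ring in place of the group of 3 heavy atoms, on an aromatic carbon, gives a 1.1-fold higher number from compound 1 to compound 3 (0.04 log units; within the scatter), which is also no difference beyond the scatter. No evidence at hand bears on these results. As far as these compounds go, whether an amine, a carboxylic acid or a longer chain in place of isopentyl would move the number beyond the scatter remains open.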